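The compounds below may be only part of what the source reports. "The series", "measured", "known", "first", "only" and "open" are said of these compounds alone.

Compound 3, `CC(C)C(=O)N1CC2CC(C1)N2`, is one of three amides built on a shared core that differ only in the group attached to the carbonyl carbon. In an assay on SH-EP1 cells for agonist activity at Neuronal acetylcholine receptor; alpha4/beta2 (Homo sapiens), read by FLIPR and calcium flux (a higher number here means a larger maximal response, a lower number a smaller maximal response), compound 3 gives 86%, the lowest of the three numbers. Compound 1, `CC(=O)N1CC2CC(C1)N2`, gives 94%, and the step of a number 8 percentage points lower from compound 1 to compound 3 (within the scatter). Compound 2, `CCCC(=O)N1CC2CC(C1)N2`, gives 120%, and the step of a number 34 percentage points lower from compound 2 to compound 3 (beyond the scatter). The remaining comparison, a number 26 percentage points higher from compound 1 to compound 2 (beyond the scatter), shows that lengthening the chain on this carbon raised the maximal response, while branching it did not move the number outside the scatter.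

Compound 4, `O=C([C@H]1C[C@@H]1F)N1CC2CC(C1)N2`, carries a different group at the same place: 2-fluorocyclopropyl in place of isopropyl on a carbonyl carbon. All three measured steps concern this position, so all bear on the change, yet none introduces a ring or a fluorine, so they give only a rough guide. Two of the three compounds sit within the scatter of each other, and compound 2 stands apart. The expectation for compound 4 is therefore a small step, a number 6 percentage points higher from compound 3 to compound 4 (within the scatter), likely within the scatter. Compound 4 is estimated at 92%, with a range from 70% to 118%.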

Compound 4, largest response reached (Emax), in percent of the reference or control that the assay uses: 100%
Compound 4: the middle estimate sits 8 percentage points below what was measured; the range from low to high includes it.
By their numbers in this assay, from the lowest: compounds 3, 1 and 4 (each within the scatter of the next, the first and the last beyond it); then compound 2.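

In this assay the ring-bearing group stands apart from the branched group it replaces (a number 14 percentage points higher from compound 3 to compound 4 (beyond the scatter)), a separation that the step from methyl to isopropyl did not show. It still falls short of the straight propyl chain (a number 20 percentage points lower from compound 2 to compound 4 (beyond the scatter)) and stays level with the small methyl group (a number 6 percentage points higher from compound 1 to compound 4 (within the scatter)), so this position accepts 2-fluorocyclopropyl without matching the response seen with propyl. No measurement available here explains these differences.

As far as these compounds go, because the ring and the fluorine enter together, the contribution of each remains open, and a plain cyclopropyl group on the same carbonyl carbon would help to separate them. From the compounds shown here alone, it is also open how the mirror-image form of 2-fluorocyclopropyl or a longer chain such as butyl would compare.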